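The compounds below may be only part of what the source reports. "The series", "measured", "known", "first", "only" and "open" are said of these compounds alone.

Measured compounds in a functional assay for agonist activity at 5-hydroxytryptamine receptor 1B (Homo sapiens); on this read-out higher numbers stand for weaker inhibition and lower numbers for stronger inhibition:
compound 1 `CC(C)NCCCOc1cccc2ccccc12` gives 7660 nM
compound 2 `NCCCOc1cccc2ccccc12` gives 290 nM
compound 3 `CCCNCCOc1cccc2ccccc12` gives 200 nM

Compound 3 holds the lowest of the three numbers. Its separation from compound 2 is a 1.5-fold lower number from compound 2 to compound 3 (0.16 log units; within the scatter), within the scatter, so the two cannot be ordered; its separation from compound 1 is a 38-fold lower number from compound 1 to compound 3 (1.58 log units; beyond the scatter). Compound 4 `CC(C)NCCOc1cccc2ccccc12` keeps the shorter linker of compound 3 and differs from it only in isopropyl in place of propyl on an amine nitrogen. Among the compounds with values here, no measured step exchanges propyl for isopropyl directly. The step that bears most closely is a 26-fold lower number from compound 1 to compound 2 (1.42 log units; beyond the scatter), where hydrogen replaced isopropyl on the amine nitrogen, on the longer linker, with a large fall in number. Read in reverse, placing isopropyl on that nitrogen has gone with a large rise, though against hydrogen rather than propyl and on a different linker. A rise beyond the scatter in this assay is therefore expected for compound 4, though not the full size of that reversed step. Compound 4 is estimated at 2000 nM, range 500 nM to 8000 nM, an expected step of a 10-fold higher number from compound 3 to compound 4 (1.00 log units; beyond the scatter).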

Compound 4, inhibition constant: 120 nM
Beside the measured number, compound 4's estimate is 17-fold (1.22 log units) above it; the whole stated range lies above it.
By their numbers in this assay, from the lowest: compounds 4, 3 and 2 (each within the scatter of the next, the first and the last beyond it); then compound 1.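

In this assay, the exchange of propyl for isopropyl on the amine nitrogen of the shorter chain gives no readable change (a 1.7-fold lower number from compound 3 to compound 4 (0.22 log units; within the scatter)), so these two groups cannot be ordered on this chain. With isopropylamino held constant, the shorter chain goes with a far lower number (a 64-fold lower number from compound 1 to compound 4 (1.81 log units; beyond the scatter)), so isopropyl on the nitrogen does not carry a high number on its own; the large rise seen earlier belongs to the combination with the longer chain. Compound 4 also separates modestly from the unsubstituted amine of compound 2 (a 2.4-fold lower number from compound 2 to compound 4 (0.38 log units; beyond the scatter)), a separation compound 3 did not reach.

Still open, as far as these compounds go, is how a primary amine on the shorter chain, a propyl group on the longer chain, or a tert-butyl or cyclopropyl group on the nitrogen would read. No supporting data explain why the outcome for isopropyl depends on chain length.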